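The compounds below may be only part of what the source reports. "The series", "measured", "known", "first", "only" and "open" are said of these compounds alone.

Compound 1 `C[C@@H](Cn1ccc(-c2ccc(C#N)c(Cl)c2)n1)NS(=O)(=O)c1cccnc1` — in an ADME assay on PC-3 cells (Homo sapiens) for cytotoxicity, read by CCK-8 assay, with a stated time of 6 days (a higher number here means a weaker inhibitor, a lower number a stronger inhibitor), compound 1 gives > 30000 nM, which is a limit of the assay and not a number.
Compound 2 `C[C@@H](Cn1ccc(-c2ccc(C#N)c(Cl)c2)n1)Nc1cccnc1` — in this assay compound 2 gives > 30000 nM, again a limit rather than a number.
Compound 3 `C[C@@H](Cn1ccc(-c2ccc(C#N)c(Cl)c2)n1)Nc1cncnc1` — in this assay compound 3 gives > 30000 nM, also a limit.

Compound 3 therefore stands exactly where the other two stand: at the limit of > 30000 nM in this assay, at which 3 of the 3 values shown sit. Among the measured compounds shown here, no measured compound has a readable number, so none can be called weaker or stronger than another. The three measured steps, a step that the two limits leave unreadable from compound 1 to compound 2, a step that the two limits leave unreadable from compound 1 to compound 3 and a step that the two limits leave unreadable from compound 2 to compound 3, cannot be sized because the limit of > 30000 nM in this assay, at which 3 of the 3 values shown sit, holds both ends of each of them; all they show is that changing the group on the amine nitrogen between these three options left every compound at the limit.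

Compound 4 `C[C@@H](Cn1ccc(-c2ccc(C#N)c(Cl)c2)n1)Nc1ncnc2nc[nH]c12` continues this series with the change (a group of 9 heavy atoms (5 carbon, 4 nitrogen; one five-membered aromatic ring with 2 hetero atoms, one six-membered aromatic ring with 2 hetero atoms) in place of a group of 6 heavy atoms (4 carbon, 2 nitrogen; one six-membered aromatic ring with 2 hetero atoms), on an amine nitrogen). All three measured steps bear on it in the sense that each also alters the group on that amine nitrogen, and none of them produced a readable number. The expectation for compound 4 in this assay is therefore that it too will sit at the limit, with the step of a number no higher from compound 3 to compound 4 (the limit leaves the size open) expected to show nothing beyond the scatter. The estimate for compound 4 is 30000 nM, with a range from 10000 nM to 60000 nM, and a high chance that only a limit is reported.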

Compound 4, half-maximal inhibitory concentration: 14100 nM
Beside the measured number, compound 4's estimate is 2.1-fold (0.33 log units) above it; the measured number falls inside the stated range.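

Among the compounds shown here, compound 4 is the first to leave the limit in this assay, so the group on this amine nitrogen can move the read-out, and here the number falls, which means a stronger inhibitor. Against the pyrimidin-5-yl group, the new group with its five-membered and six-membered aromatic rings gives an at least 2.1-fold lower number from compound 3 to compound 4 (0.32 log units; beyond the scatter), and the same group also gives an at least 2.1-fold lower number from compound 2 to compound 4 (0.32 log units; beyond the scatter) and an at least 2.1-fold lower number from compound 1 to compound 4 (0.32 log units; beyond the scatter); the last step replaces a group of 9 heavy atoms with another group of 9 heavy atoms, so the heavy-atom count alone does not separate these two compounds. Each of these steps gives only a minimum size, because its starting compound has a limit and not a number: the limit of > 30000 nM in this assay, at which 3 of the 4 values shown sit.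

The compounds shown cannot separate the roles of the five-membered ring, the ring nitrogens and the hydrogen-bond donor in the entering group. On these data alone, how a fused group made of carbon atoms only, such as naphthyl, would read in this assay also stays open.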